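This account rests on a few compounds, and the source may have more. Where it says the series, first, only, none or still open, it means among the compounds named here.

- compound 1 `Fc1ccc(-c2nn(-c3ccccc3)cc2-c2nc3cc(F)ccc3[nH]2)cc1`: 950 nM
- compound 2 `Fc1ccc(-c2nn(-c3ccccc3)cc2-c2nc3cc(Br)ccc3[nH]2)cc1`: 3210 nM

In a functional assay on MCF7 cells (Homo sapiens) for antiproliferative activity, read by MTT assay, with a stated time of 48 h (on this read-out higher numbers stand for weaker inhibition and lower numbers for stronger inhibition), compound 2, at 3210 nM, holds the higher of the two numbers. Compound 3 `COc1ccc2[nH]c(-c3cn(-c4ccccc4)nc3-c3ccc(F)cc3)nc2c1` carries the next change: methoxy in place of bromo on an aromatic carbon. Going by the values given here, the only measured step bearing on this substituent is a 3.4-fold higher number from compound 1 to compound 2 (0.53 log units; beyond the scatter), for bromo in place of fluoro. Among the compounds with values here, no methoxy compound has been measured, so a modest step toward a lower number is expected, though it may stay within the scatter. The estimated step is a 1.8-fold lower number from compound 2 to compound 3 (0.25 log units; within the scatter). For compound 3 the estimated value is 1800 nM, with an expected range of 700 nM to 4800 nM.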

Compound 3, half-maximal inhibitory concentration: 970 nM
Estimate against measurement, compound 3: 1.9-fold (0.27 log units) above, within the range that was stated.
By their numbers in this assay, from the lowest: compounds 1 and 3 (each within the scatter of the next); then compound 2.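

In this assay, this position carries methoxy with no loss against fluoro: methoxy in place of fluoro gives a 1.0-fold higher number from compound 1 to compound 3 (0.01 log units; within the scatter), whereas methoxy in place of bromo gives a 3.3-fold lower number from compound 2 to compound 3 (0.52 log units; beyond the scatter). Among the three groups, bromo alone stands apart, and methoxy, with 2 heavy atoms against 1 for bromo, does not follow it toward a higher number. Nothing on hand explains this difference.

Still open, going by these compounds, is whether an amine, a carboxylic acid or a longer chain such as butoxy at this position would stay with fluoro and methoxy or move toward bromo.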